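A few compounds are considered here, and "the series" means these few. Any claim that something is new, unique, unknown or untested is made for them only; others in the source may bear on it.

Within the data shown here, compound 1 `CC(=O)OCCOCN1c2ccccc2C(=O)NS1(=O)=O` is one of three compounds measured in a functional assay on CCRF-CEM cells (Homo sapiens) for cytotoxicity; a higher number here means that more compound is tolerated, a lower number that less compound is tolerated. In this assay compound 1 gives > 200 ug/mL, which is a limit of the measurement and not a number. Compound 2 `CCCOCN1c2ccccc2C(=O)NS1(=O)=O` in this assay gives > 200 ug/mL, again a limit. Compound 3 `O=C1c2ccccc2NS(=O)(=O)N1Cc1ccccc1` in this assay gives > 200 ug/mL, a limit as well. Among the measured compounds shown here, the one step that links two measured compounds differing in a single place, a step that the two limits leave unreadable from compound 1 to compound 2, therefore cannot be read in size. What remains as evidence is the limit of > 200 ug/mL in this assay, at which 3 of the 3 values shown sit. Compound 4 `CC(=O)OCCOCN1c2ccccc2C(=O)N(Cc2ccccc2)S1(=O)=O` differs from compound 1 by benzyl in place of hydrogen on an amide-type nitrogen in a ring. For the measured compounds named here, compound 3 also bears a benzyl group and sits at the limit, but no step connects it to another measured compound, so its value shows only that much. Going by the values given here, none of the measured steps bears directly on the benzyl change, and none shows a change beyond the scatter. The step from compound 1 to compound 4 is accordingly expected to be none beyond the scatter, a step that the limit leaves unreadable from compound 1 to compound 4. Compound 4 is expected to give about 250 ug/mL in this assay, within a range from 100 ug/mL to 600 ug/mL, and most likely to be reported once more only as a limit.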

Compound 4, half-maximal cytotoxic concentration: 103 ug/mL
Estimate against measurement, compound 4: 2.4-fold (0.39 log units) above, and the stated range covers the measured number.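

In this assay, among these compounds, compound 4 gives 103 ug/mL, the first value in this set that is a number and not a limit, and it carries benzyl and (2-acetoxyethoxy)methyl on the two ring nitrogens at once. Benzyl in place of hydrogen on the amide-type nitrogen gives an at least 1.9-fold lower number from compound 1 to compound 4 (0.28 log units; that floor lies within the scatter), while (2-acetoxyethoxy)methyl in place of hydrogen on the sulfonamide nitrogen gives an at least 1.9-fold lower number from compound 3 to compound 4 (0.28 log units; that floor lies within the scatter). Each step is therefore only a floor that does not pass the scatter, so a real drop is possible but not shown, and its true size cannot be read because the other compounds stay at a limit: the limit of > 200 ug/mL in this assay, at which 3 of the 4 values shown sit.

As far as these compounds go, it remains open whether the number seen with compound 4 depends on the benzyl ring itself or on having any group on that nitrogen at all, which a methyl or a longer chain there could separate. From the compounds shown here alone, it is equally open how a benzyl carrying an amine or a carboxylic acid would behave, and whether any such change would bring a step clearly beyond the scatter.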